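A few compounds are considered here, and "the series" means these few. Any claim that something is new, unique, unknown or untested is made for them only; others in the source may bear on it.

The measured compounds are compound 1 `O=C1/C(=C/c2ccc(F)cc2)CCC/C1=C\c1ccccc1[N+](=O)[O-]` with 1510 nM, compound 2 `O=C1/C(=C/c2ccc(F)cc2)CCC/C1=C\c1ccc([N+](=O)[O-])cc1` with 18600 nM, and compound 3 `O=C1/C(=C/c2ccc(Cl)cc2)CCC/C1=C\c1ccc([N+](=O)[O-])cc1` with 8180 nM.

All three numbers come from a functional assay on CCRF-CEM cells (Homo sapiens) for cytotoxicity, with a stated time of 72 h; a higher number here means a weaker inhibitor, a lower number a stronger inhibitor. Compound 1 stands lowest of the three, and its values against compound 2 and compound 3 lie beyond the scatter. Compound 1 and compound 2 are built from the same atoms joined differently; the difference between the two cores is not broken down here. Compound 2 and compound 3 differ by chloro in place of fluoro on an aromatic carbon, and that step gave a 2.3-fold lower number from compound 2 to compound 3 (0.36 log units; beyond the scatter).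

Compound 4 `O=C1/C(=C/c2ccc(Cl)cc2)CCC/C1=C\c1ccccc1[N+](=O)[O-]` has not yet been measured. It differs from compound 1 by chloro in place of fluoro on an aromatic carbon, the same change at the same place. For compound 4 a step of a 2.2-fold lower number from compound 1 to compound 4 (0.33 log units; beyond the scatter) is expected because the same change gave a 2.3-fold lower number from compound 2 to compound 3 (0.36 log units; beyond the scatter). Compound 4 is therefore estimated at 700 nM, between 300 nM and 1600 nM.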

Compound 4, half-maximal inhibitory concentration: 1750 nM
The estimate for compound 4 lay 2.5-fold (0.40 log units) below the measured number; the measured number lies above the stated range.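

In this assay, chloro in place of fluoro gave a 1.2-fold higher number from compound 1 to compound 4 (0.06 log units; within the scatter), so on the core of compound 1 this change leaves the number within the scatter. Set beside the step on the other core, the two results do not separate: the same change on two cores in this assay, a 2.3-fold lower number (0.36 log units; beyond the scatter) from compound 2 to compound 3 and a 1.2-fold higher number (0.06 log units; within the scatter) from compound 1 to compound 4, 2.6-fold (0.42 log units) apart, within the scatter of two such steps. Going by these compounds alone, this shows no measurable difference between the two cores for this change, but it does not show that the change carries over reliably, as each core offers only one pair, and one step lies beyond the scatter while the other lies within it.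

The compounds shown leave open how a methoxy group or an amine would behave on the aromatic carbon that carries fluoro or chloro. They also leave open what a nitrile in place of the nitro group would do on either core.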